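The source may hold more compounds than are shown below. What is called first, only, known or untested is meant among the compounds shown, and "the series" means these compounds.

In a functional assay on U-251 cells (Homo sapiens) for antiproliferative activity, read by MTT assay, with a stated time of 24 h (a lower number here means a stronger inhibitor, a higher number a weaker inhibitor), three compounds sharing one core have been measured. Compound 1 `C=CCOc1ccc2c(=O)c(-c3cc(OC)c(OC)cc3OC)coc2c1` gives 5900 nM and compound 2 `C#CCOc1ccc2c(=O)c(-c3cc(OC)c(OC)cc3OC)coc2c1` gives 6450 nM, and a 1.1-fold higher number from compound 1 to compound 2 (0.04 log units; within the scatter) leaves them level. Compound 3 `COc1cc(OC)c(-c2coc3cc(OCc4ccccc4C)ccc3c2=O)cc1OC`, at 2000 nM, holds the lowest number of the three, with a 3.0-fold lower number from compound 1 to compound 3 (0.47 log units; beyond the scatter) and a 3.2-fold lower number from compound 2 to compound 3 (0.51 log units; beyond the scatter), both modest. Compound 4 `COc1cc(OC)c(-c2coc3cc(OCc4ccccc4Cl)ccc3c2=O)cc1OC` carries chloro in place of methyl on an aromatic carbon, ortho to a large group: chloro in place of methyl on an aromatic carbon. Among the compounds with values here, no measured step makes this exchange. The nearest steps replace the whole 2-methylphenyl group and remain modest, so a change of one heavy atom is expected to stay smaller. The expected change is a 1.1-fold lower number from compound 3 to compound 4 (0.05 log units; within the scatter), which is not beyond the scatter. Compound 4 is estimated at 1800 nM, with an expected range of 800 nM to 4000 nM.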

Compound 4, half-maximal inhibitory concentration: > 10000 nM
Compound 4 gave a limit, no number; the forecaster's own chance of this, stated with the estimate: 2%; middle value at least 5.5-fold (0.74 log units) away from the limit.
By their numbers in this assay, from the lowest: compound 3; then compounds 1 and 2 (each within the scatter of the next). At a limit, above all of these: compound 4.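

In this assay compound 4 gives a limit, not a number: the limit of > 10000 nM in this assay, at which 1 of the 4 values shown sits. On this aromatic carbon, ortho to a large group, the exchange of one heavy atom is not a small change: the step shows an at least 5.0-fold higher number from compound 3 to compound 4 (0.69 log units; beyond the scatter), so methyl and chloro are not interchangeable here. The other steps are looser, with an at least 1.5-fold higher number from compound 2 to compound 4 (0.19 log units; that floor lies within the scatter) and an at least 1.6-fold higher number from compound 1 to compound 4 (0.22 log units; that floor lies within the scatter).

From the compounds shown here alone, whether fluoro, methoxy or an unsubstituted benzyl group would keep the number of compound 3 or lose it stays open. Going by these compounds, how far compound 4 lies past its limit also stays open.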